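Swapping cyclopropyl for methyl on compound 2

This account rests on a few compounds, and the source may have more. Where it says the series, first, only, none or still open, it means among the compounds named here.

Of the compounds shown here, three sharing one core have been tested in a functional assay (strain AB) with Danio rerio as the target, read by microscopy, with a stated time of 1 h; on this read-out lower numbers stand for an effect already at smaller amounts and higher numbers for an effect only at larger amounts of compound. Compound 2 `CC[N+]1(CC2CC2)CCc2c(sc(NC(=O)Nc3ccc(Cl)cc3)c2C(N)=O)C1` gives 100 nM, and compound 1 `CC(C)(C)OC(=O)CCCCC[N+]1(C)CCc2c(sc(NC(=O)Nc3ccc(Cl)cc3)c2C(N)=O)C1` gives 110 nM, so these two lie within the scatter of each other. Compound 3 `C[N+]1(CC2CC2)CCc2c(sc(NC(=O)Nc3ccc(Cl)cc3)c2C(N)=O)C1` gives 360 nM, clearly the highest number of the three.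

The open question is compound 4 `CC[N+]1(CC)CCc2c(sc(NC(=O)Nc3ccc(Cl)cc3)c2C(N)=O)C1`, which differs from compound 2 as follows: methyl in place of cyclopropyl on a saturated chain carbon bound to an amine nitrogen in a ring. Put shortly, cyclopropylmethyl becomes ethyl.

For the measured compounds named here, no measured step makes exactly this change, but two come close. Each puts a smaller group on the same kind of carbon: a 3.6-fold higher number from compound 2 to compound 3 (0.56 log units; beyond the scatter), and a 3.3-fold higher number from compound 1 to compound 3 (0.51 log units; beyond the scatter). Both are modest and point the same way, towards a higher number, and neither of the three compounds goes against this. With only these two steps as a guide, a similar modest rise seems likely in this assay, perhaps somewhat smaller than either.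

The expected step is a 2.3-fold higher number from compound 2 to compound 4 (0.36 log units; beyond the scatter).

For compound 4 the estimated value is 230 nM, within an expected range of 90 nM to 550 nM.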

Compound 4, half-maximal effective concentration: 450 nM
Beside the measured number, compound 4's estimate is 2.0-fold (0.29 log units) below it; low and high end bracket the measured number.
By their numbers in this assay, from the lowest: compounds 2 and 1 (each within the scatter of the next); then compounds 3 and 4 (each within the scatter of the next).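

In this assay the new result, a 4.5-fold higher number from compound 2 to compound 4 (0.65 log units; beyond the scatter), shows that the cyclopropyl on a saturated chain carbon bound to an amine nitrogen in a ring also counts towards the low number of compound 2, and that replacing it with methyl gives a step beyond the scatter. The earlier step in this family, a 3.6-fold higher number from compound 2 to compound 3 (0.56 log units; beyond the scatter), changed only the other group on that nitrogen, ethyl to methyl, and left cyclopropylmethyl in place, so compound 2 now loses ground when either of these two groups is cut back. No measurement shown here explains why either change raises the number.

The change from cyclopropylmethyl to ethyl removes the ring and shortens the group at once, so compounds 2 and 4 cannot say which of the two matters; a straight propyl or butyl chain, or a cyclobutylmethyl group, in the same place would begin to separate them. On these data alone, it also remains open how this position responds to groups of another kind, such as an amine or a carboxylic acid at the end of the chain.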